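Replacing Methylamino with Trifluoromethyl on the Pyridyl Arm

The source may report more compounds than this note shows. Statements on the series, on what has been measured and on what is new or still open speak of the compounds shown alone.

The measured compounds, all read in an assay on T-REx-293 cells for inhibition of potassium channel subfamily T member 1 (Mus musculus), read by patch clamp; a higher number here means a weaker inhibitor, a lower number a stronger inhibitor:

compound 1, `COc1cc(-c2noc([C@H](C)NC(=O)c3cc(C(F)(F)F)nn3C)n2)ccn1`, gives 3000 nM.
compound 2, `COCc1cc(-c2noc([C@H](C)NC(=O)c3cc(C(F)(F)F)nn3C)n2)ccn1`, gives 17100 nM.
compound 3, `CNc1cc(-c2noc([C@H](C)NC(=O)c3cc(C(F)(F)F)nn3C)n2)ccn1`, gives only a limit of the assay, > 30000 nM.

Compound 3 is the weakest of the three, and its figure is a limit rather than a number (the limit of > 30000 nM in this assay, at which 1 of the 3 values shown sits). The step to it from compound 1 was an at least 10-fold higher number from compound 1 to compound 3 (1.00 log units; beyond the scatter), while the step from compound 2 was an at least 1.7-fold higher number from compound 2 to compound 3 (0.24 log units; that floor lies within the scatter). Compound 4, `C[C@H](NC(=O)c1cc(C(F)(F)F)nn1C)c1nc(-c2ccnc(C(F)(F)F)c2)no1`, differs from compound 3 by trifluoromethyl in place of methylamino on an aromatic carbon. Going by the values given here, none of the measured steps swaps in a trifluoromethyl, so they bear only loosely on this change; they show that the group on that carbon moves the number strongly, with methoxy at the low end and methylamino at the limit. Since compound 3 sits at the limit, a move in either direction is possible, but a lower number is expected for compound 4, namely 12000 nM, between 2000 nM and 60000 nM, a step of an at least 2.5-fold lower number from compound 3 to compound 4 (0.39 log units; beyond the scatter).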

Compound 4, half-maximal inhibitory concentration in the potassium channel subfamily T member 1 assay: 622 nM
Estimate against measurement, compound 4: 19-fold (1.29 log units) above; the measured number lies below the stated range.
By their numbers in the potassium channel subfamily T member 1 assay, from the lowest: compound 4; then compound 1; then compound 2. At a limit, above all of these: compound 3.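

In the potassium channel subfamily T member 1 assay, trifluoromethyl on this carbon, next to the ring nitrogen, is the first group shown to outdo methoxy, with a 4.8-fold lower number from compound 1 to compound 4 (0.68 log units; beyond the scatter), and the distance to the other two groups is larger, with a 27-fold lower number from compound 2 to compound 4 (1.44 log units; beyond the scatter) and an at least 48-fold lower number from compound 3 to compound 4 (1.68 log units; beyond the scatter). That last step is only a floor: in the potassium channel subfamily T member 1 assay compound 3 has just a limit of the assay, > 30000 nM. In a physicochemical assay for solubility, measured as kinetic solubility (a higher number here means a more soluble compound, a lower number a less soluble compound), compound 3 gives 143000 nM and compound 4 gives 58000 nM. The same change from methylamino to trifluoromethyl also comes with lower solubility in the physicochemical assay: the measured solubility of compound 3, 143000 nM, and of compound 4, 58000 nM, a 2.5-fold lower number (0.39 log units; beyond the scatter)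

On these data alone, whether a methyl group, a chlorine atom or a nitrile on this carbon would match trifluoromethyl stays open. So does whether trifluoromethyl would give a similarly low number on another carbon of the ring.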